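A few compounds are considered here, and "the series" means these few. Any claim that something is new, unique, unknown or untested is made for them only; others in the source may bear on it.

In an ADME assay on HaCaT cells (Homo sapiens) for inhibition, read by sulforhodamine B assay, with a stated time of 48 h (on this read-out lower numbers stand for stronger inhibition of growth and higher numbers for weaker inhibition of growth), compound 3 `CC(C)(C)NCc1c(C(=O)O)nn(-c2ccc(Cl)cc2)c1-c1ccc(Br)cc1` gives > 542000 nM, which is a limit of the assay and not a number. The chloro counterpart, compound 2 `CC(C)(C)NCc1c(C(=O)O)nn(-c2ccc(Cl)cc2)c1-c1ccc(Cl)cc1`, gives 87500 nM. The measured step of an at least 6.1-fold higher number from compound 2 to compound 3 (0.79 log units; beyond the scatter) lies beyond the scatter, but it exchanges chloro for bromo and so bears on the present change only indirectly. Also carrying 4-methylphenyl, compound 1 `CCOC(=O)c1nn(-c2ccc(Cl)cc2)c(-c2ccc(C)cc2)c1CNC(C)(C)C` gives 144000 nM; > 542000 nM (2 entries). Compound 4 `Cc1ccc(-c2c(CNC(C)(C)C)c(C(=O)O)nn2-c2ccc(Cl)cc2)cc1` differs from compound 3 by methyl in place of bromo on an aromatic carbon, with methyl in place of bromo on an aromatic carbon. A modest step toward a lower number, an at least 2.7-fold lower number from compound 3 to compound 4 (0.43 log units; beyond the scatter), is expected. Compound 4 is estimated at 200000 nM, with an expected range of 70000 nM to 542000 nM.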

Compound 4, concentration for 50% growth inhibition: > 629000 nM
Compound 4: only a limit was reported (the forecaster's own chance of this, stated with the estimate: 40%); middle value at least 3.1-fold (0.49 log units) from the limit.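

In this assay, compound 4 gives > 629000 nM, which is a limit of the assay and not a number. Methyl in place of chloro on this aromatic carbon gives an at least 7.1-fold higher number from compound 2 to compound 4 (0.85 log units; beyond the scatter), so compound 2 alone among the three carboxylic acids carries a single number. Compound 3 and compound 4 both stand at limits, and the step between them cannot be read.

On these data alone, how bromo and methyl rank against each other stays open. So does whether fluoro or methoxy at this position would give a readable number.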